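This account rests on a few compounds, and the source may have more. Where it says the series, first, only, none or still open, it means among the compounds named here.

Measured compounds:

Compound 1, `O=C(N/N=C/c1ccccc1)c1cccnc1Nc1cccc(C(F)(F)F)c1`: 53.9%
Compound 2, `O=C(N/N=C/c1cccc(Cl)c1)c1cccnc1Nc1cccc(C(F)(F)F)c1`: 76.7%

In a functional assay on the whole organism (strain Wistar) for inhibition, with Rattus norvegicus as the target, read by paw edema, with a stated time of 1 h, at a dose of 10 mg/kg by the intraperitoneal route (on this read-out higher numbers stand for more inhibition at the one dose given (going by the name of the read-out) and lower numbers for less inhibition), compound 2 gives the higher of the two numbers, with compound 1 the nearer one, and a number 22.8 percentage points higher from compound 1 to compound 2 (beyond the scatter) puts that single step beyond the scatter. Compound 3, `O=C(N/N=C/c1ccc(Cl)cc1)c1cccnc1Nc1cccc(C(F)(F)F)c1`, is built from compound 2 by the change (4-chlorophenyl in place of 3-chlorophenyl on a carbon with a double bond to nitrogen); the two share every atom and differ only in how the chlorine sits on the ring. Within the data shown here, no measured step moves a chlorine between ring positions, so the only step in hand, a number 22.8 percentage points higher from compound 1 to compound 2 (beyond the scatter), tells what adding a chlorine did, not what shifting it does. With nothing pointing one way, the expectation for this assay is a step near zero, a number 5.7 percentage points lower from compound 2 to compound 3 (within the scatter), most likely within the scatter. Compound 3 is therefore estimated at 71%, with a range from 52% to 88%.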

Compound 3, a percentage reported as inhibition, in the whole organism at one dose (the size of the read-out at that dose, not a potency): 67.2%
Compound 3: middle estimate off by 3.8 percentage points, on the high side; the range from low to high includes it.
By their numbers in this assay, from the lowest: compound 1; then compounds 3 and 2 (each within the scatter of the next).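

In this assay, moving the chlorine from 3-chlorophenyl to 4-chlorophenyl on the carbon with a double bond to nitrogen gives a number 9.5 percentage points lower from compound 2 to compound 3 (within the scatter), so this assay does not tell the two placements apart. Chlorine in the 4-chlorophenyl form still gives a number 13.3 percentage points higher from compound 1 to compound 3 (beyond the scatter), which means that the step up with chlorine is not confined to the 3-chlorophenyl form, as both chlorinated compounds lie beyond the scatter from the compound without chlorine. Nothing measured on these compounds bears on what lies behind these numbers.

As far as these compounds go, whether the rise needs chlorine itself remains open, since a methyl group, a methoxy group or an amine on the same ring could do as much, or nothing. The compounds shown also leave untested how the trifluoromethyl group on the shared core contributes.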